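Two Fluorines Added to a Highly Soluble Amide

This account rests on a few compounds, and the source may have more. Where it says the series, first, only, none or still open, it means among the compounds named here.

Compound 1 `CN1CCC(C(=O)N2Cc3c(NC(=O)c4ccccc4)n[nH]c3C2(C)C)CC1` has been tested in a physicochemical assay for solubility, at pH 7; a higher number here means a more soluble compound, a lower number a less soluble compound. Compound 1 gives > 225000 nM, which is a limit of the assay rather than a number. Compound 2 `CC(=O)N1CCN(C(=O)N2Cc3c(NC(=O)c4ccc(F)cc4)n[nH]c3C2(C)C)CC1` also reaches a limit, > 225000 nM, in this assay. Taken together, (the limit of > 225000 nM in this assay, at which 2 of the 2 values shown sit). Compound 3 `CN1CCC(C(=O)N2Cc3c(NC(=O)c4ccc(F)c(F)c4)n[nH]c3C2(C)C)CC1` differs from compound 1 by 3,4-difluorophenyl in place of phenyl on a carbonyl carbon. For the measured compounds named here, because both known values sit at the limit of > 225000 nM in this assay, at which 2 of the 2 values shown sit, no measured step is available to guide the expectation. The step of a number no higher from compound 1 to compound 3 (the limit leaves the size open) is expected to be none beyond the scatter. Compound 3 is therefore expected to give 225000 nM, between 80000 nM and 225000 nM, most likely again as a limit.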

Compound 3, solubility: > 225000 nM
Compound 3 ended at the assay's limit (the forecaster's own chance of this, stated with the estimate: 70%); the middle value lies on the limit itself.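

Compound 1 and compound 3 both end at a limit rather than a number in this assay, so no step can be read between them: the limit of > 225000 nM in this assay, at which 3 of the 3 values shown sit.

On these data alone, whether 3,4-difluorophenyl in place of phenyl makes any difference in this assay stays open.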